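Three Ureas Compared and a Fourth Awaited

This account rests on a few compounds, and the source may have more. Where it says the series, first, only, none or still open, it means among the compounds named here.

Compound 1 `Cc1ccc(NC(=O)Nc2cccc(CNc3nccnc3Cl)c2)cc1C` gives 10700 nM in a functional assay on HepG2 cells (Homo sapiens) for antiproliferative activity, read by MTT assay, with a stated time of 48 h; a higher number here means a weaker inhibitor, a lower number a stronger inhibitor. Among the three measured compounds it stands second highest; its nearest neighbour is compound 3 `Cc1ccc(NC(=O)Nc2cccc(CNc3nccnc3Cl)c2)cc1Cl` with 11300 nM, a step of a 1.1-fold higher number from compound 1 to compound 3 (0.02 log units; within the scatter), and the furthest is compound 2 `CCOc1ccc(NC(=O)Nc2cccc(CNc3nccnc3Cl)c2)cc1` with 7050 nM, a step of a 1.5-fold lower number from compound 1 to compound 2 (0.18 log units; within the scatter). Compound 4 `O=C(Nc1cccc(CNc2nccnc2Cl)c1)Nc1ccccc1F` differs from compound 1 by 2-fluorophenyl in place of 3,4-dimethylphenyl on an amide-type nitrogen. For the measured compounds named here, the steps that bear on such a swap of the aryl group on the amide-type nitrogen are a 1.5-fold lower number from compound 1 to compound 2 (0.18 log units; within the scatter) and a 1.6-fold higher number from compound 2 to compound 3 (0.20 log units; within the scatter), both within the scatter. Compound 4 is therefore expected to move no further than the scatter, a 1.1-fold lower number from compound 1 to compound 4 (0.03 log units; within the scatter). The estimated value of compound 4 in this assay is 10000 nM, expected between 4000 nM and 25000 nM.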

Compound 4, half-maximal inhibitory concentration: 10500 nM
The estimate for compound 4 lay 1.1-fold (0.02 log units) below the measured number, and the stated range covers the measured number.
By their numbers in this assay, from the lowest: compounds 2, 4, 1 and 3 (each within the scatter of the next).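

In this assay the 2-fluorophenyl group on the amide-type nitrogen reads the same as each earlier aryl group, and all three steps stay within the scatter: (a 1.0-fold lower number from compound 1 to compound 4 (0.01 log units; within the scatter)), (a 1.1-fold lower number from compound 3 to compound 4 (0.03 log units; within the scatter)) and (a 1.5-fold higher number from compound 2 to compound 4 (0.17 log units; within the scatter)). A ring carrying only fluorine thus joins the methyl, chloro and ethoxy rings with no measurable shift at this position. No measurement shown accounts for this flat response. As far as these compounds go, whether an amine or a carboxylic acid on this ring would move the number beyond the scatter stays open. So does the effect of a longer chain on the amide-type nitrogen.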